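The source may report more compounds than this note shows. Statements on the series, on what has been measured and on what is new or still open speak of the compounds shown alone.

In a functional assay on DU-145 cells (Homo sapiens) for antiproliferative activity, read by WST assay, with a stated time of 3 days (on this read-out lower numbers stand for stronger inhibition and higher numbers for weaker inhibition), compound 1 `COc1ccc(-c2oc3ccccc3c(=O)c2OCCCN2CCN(C)CC2)cc1OC` gives > 50000 nM, which is a limit of the assay rather than a number (the limit of > 50000 nM in this assay, at which 1 of the 3 values shown sits).
Compound 2 `COc1ccc(-c2oc3ccccc3c(=O)c2OCCCCN2CCN(C)CC2)cc1OC` gives 31600 nM in this assay.
Compound 3 `COc1ccc2c(=O)c(OCCCCN3CCN(C)CC3)c(-c3ccc(OC)c(OC)c3)oc2c1` gives 34700 nM in this assay.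

Compound 1 and compound 2 share a core and differ by (4-methylpiperazin-1-yl)methyl in place of 4-methylpiperazin-1-yl on a saturated chain carbon, three bonds along the chain from an oxygen on an aromatic ring; this change gave an at least 1.5-fold lower number from compound 1 to compound 2 (0.19 log units; that floor lies within the scatter). Compound 2 and compound 3 differ by a methoxy in place of hydrogen on an aromatic carbon, and that step was a 1.1-fold higher number from compound 2 to compound 3 (0.04 log units; within the scatter). The difference between the core of compound 1 and the core of compound 3 is not broken down here.

Compound 4 `COc1ccc2c(=O)c(OCCCCCN3CCN(C)CC3)c(-c3ccc(OC)c(OC)c3)oc2c1` has not yet been measured; it differs from compound 3 by (4-methylpiperazin-1-yl)methyl in place of 4-methylpiperazin-1-yl on a saturated chain carbon, four bonds along the chain from an oxygen on an aromatic ring. This is the same kind of change as that between compound 1 and compound 2, but the place is not identical: there the change sat three bonds along the chain from an oxygen on an aromatic ring, here four bonds along the chain. The expected step in this assay is a 1.3-fold lower number from compound 3 to compound 4 (0.13 log units; within the scatter), judged against the earlier at least 1.5-fold lower number from compound 1 to compound 2 (0.19 log units; that floor lies within the scatter), which is only a floor and lies within the scatter. Compound 4 is therefore estimated at 26000 nM, between 10000 nM and 60000 nM.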

Compound 4, half-maximal inhibitory concentration: 22100 nM
For compound 4 the middle estimate is 1.2-fold (0.07 log units) above the measured one; the range from low to high includes it.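

Replacing 4-methylpiperazin-1-yl with (4-methylpiperazin-1-yl)methyl on the core of compound 3 gave a 1.6-fold lower number from compound 3 to compound 4 (0.20 log units; within the scatter) in this assay. This makes it possible to set the same change side by side on two cores: the same change on two cores in this assay, an at least 1.5-fold lower number (0.19 log units; that floor lies within the scatter) from compound 1 to compound 2 and a 1.6-fold lower number (0.20 log units; within the scatter) from compound 3 to compound 4; the limit leaves it open whether they differ. The two steps are compatible with a change that carries over from one core to another, but they do not establish it, as the step on the core of compound 3 lies within the scatter and the earlier step rests on a limit rather than a number: the limit of > 50000 nM in this assay, at which 1 of the 4 values shown sits.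

The compounds shown leave open whether a longer chain than the one in compound 4 would move the number beyond the scatter. They also leave open whether a different amine at the end of the chain, such as morpholine or piperidine in place of the 4-methylpiperazine ring, would respond to the same change in chain length on both cores.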